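Fluoro to Bromo: Estimating Macrophage Cytotoxicity for Compound 4

The source may report more compounds than this note shows. Statements on the series, on what has been measured and on what is new or still open speak of the compounds shown alone.

Of the compounds shown here, three have been measured in an ADME assay on cells (Macrophage, Mus musculus) for cytotoxicity, read by resazurin assay, with a stated time of 3 days; a lower number here means a stronger inhibitor, a higher number a weaker inhibitor. Compound 1 `O=C(Nc1cc(C(F)(F)F)cc(C(F)(F)F)c1)c1cc(F)ccc1O` gives 2500 nM, compound 2 `O=C(Nc1cc(C(F)(F)F)cc(C(F)(F)F)c1)c1cc(Br)ccc1O` gives 4900 nM, and compound 3 `O=C(Nc1cccc(F)c1)c1cc(Cl)ccc1O` gives 15000 nM, the highest of the three. From compound 1 to compound 2 the change is bromo in place of fluoro on an aromatic carbon, and this produced a 2.0-fold higher number from compound 1 to compound 2 (0.29 log units; within the scatter). Compound 4 `O=C(Nc1cccc(Br)c1)c1cc(Cl)ccc1O` is not yet measured; it differs from compound 3 by bromo in place of fluoro on an aromatic carbon. This is the same kind of change, though in compound 1 the place is also para to a hydroxy group, while in compound 3 it is only meta to a large group. The difference between the two cores is not broken down here. Because the earlier step of a 2.0-fold higher number from compound 1 to compound 2 (0.29 log units; within the scatter) stayed within the scatter, a similarly small step is expected in this assay: a 1.3-fold higher number from compound 3 to compound 4 (0.12 log units; within the scatter). Compound 4 is therefore estimated at 20000 nM, probably between 8000 nM and 50000 nM.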

Compound 4, half-maximal inhibitory concentration: 5700 nM
Beside the measured number, compound 4's estimate is 3.5-fold (0.55 log units) above it; the whole stated range lies above it.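

In this assay, putting bromo in place of fluoro gave a 2.6-fold lower number from compound 3 to compound 4 (0.42 log units; beyond the scatter), so in this series the step measured on one core cannot simply be carried over to another. The two steps differ by more than their scatter: the same change on two cores in this assay, a 2.0-fold higher number (0.29 log units; within the scatter) from compound 1 to compound 2 and a 2.6-fold lower number (0.42 log units; beyond the scatter) from compound 3 to compound 4, 5.2-fold (0.71 log units) apart, beyond the scatter of two such steps. Going by these compounds alone, with only one pair on each core, this does not show which difference between the cores matters, and the change also sits in a different place in each pair, so it does not predict the step on any further core.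

The compounds shown leave open how an amine or a carboxylic acid in place of the bromo of compound 4 would read in this assay.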